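Notes on compound 3 and the unmeasured compound 4

A few compounds are considered here, and "the series" means these few. Any claim that something is new, unique, unknown or untested is made for them only; others in the source may bear on it.

Of the compounds shown here, three are measured so far. Compound 1 `COc1ccc(OC(=O)Nc2ccc([Se]C#N)cc2)cc1` gives 13000 nM in a functional assay on CCRF-CEM cells (Homo sapiens) for cytotoxicity, read by MTT assay, with a stated time of 72 h; a higher number here means a weaker inhibitor of growth, a lower number a stronger inhibitor of growth. Compound 2 `O=C(Nc1ccc([Se][Se]c2ccc(NC(=O)OCc3ccccc3)cc2)cc1)OCc1ccccc1` gives 6400 nM in this assay. Compound 3 `CCCCOC(=O)Nc1ccc([Se]C#N)cc1` gives 6500 nM, the second highest of the three numbers; its nearest neighbour is compound 2 and its furthest is compound 1, and both gaps lie within the scatter, so no order can be read among the three. Compound 4 `C=CCOC(=O)Nc1ccc([Se]C#N)cc1` is not yet measured; it differs from compound 3 by vinyl in place of propyl on a saturated chain carbon bound to an oxygen next to a carbonyl group. Going by the values given here, no step between measured compounds is known, so the expectation rests on the small size of this change alone. The step from compound 3 to compound 4 is expected to be a 1.1-fold lower number from compound 3 to compound 4 (0.03 log units; within the scatter), nothing beyond the scatter. Compound 4 is accordingly estimated at 6000 nM, with a range from 2500 nM to 15000 nM.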

Compound 4, concentration for 50% growth inhibition: 9200 nM
Beside the measured number, compound 4's estimate is 1.5-fold (0.19 log units) below it; the measured number falls inside the stated range.
By their numbers in this assay, from the lowest: compounds 2, 3, 4 and 1 (each within the scatter of the next, the first and the last beyond it).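

In this assay, going by these compounds alone, the first comparison that differs in one place gives a 1.4-fold higher number from compound 3 to compound 4 (0.15 log units; within the scatter) for vinyl in place of propyl on a saturated chain carbon bound to an oxygen next to a carbonyl group. At this position, butyl to allyl therefore leaves the number within the scatter. Nothing available bears on a cause for this step.

Going by these compounds, whether a longer chain or an amine at this position would move the number beyond the scatter stays open. So does whether a carboxylic acid would be tolerated there.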